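The source may hold more compounds than are shown below. What is called first, only, known or untested is meant among the compounds shown, and "the series" means these compounds.

In a physicochemical assay for lipophilicity, measured as octanol-water partition, at pH 7.4 (on this read-out higher numbers stand for higher lipophilicity and lower numbers for lower lipophilicity), compound 1 (`Cc1ccc2[nH]c(C(=O)N[C@H]3CN(S(=O)(=O)c4ccnnc4)C[C@@H]3C(=O)NCCN(C)C)cc2c1`) gives 0.7 while compound 2 (`Cc1ccc2[nH]c(C(=O)N[C@H]3CN(S(=O)(=O)c4cn(C)nc4C)C[C@@H]3C(=O)NCCN(C)C)cc2c1`) gives 1.4 and compound 3 (`Cc1ccc2[nH]c(C(=O)N[C@H]3CCN(S(=O)(=O)c4cccnc4)C[C@@H]3C(=O)NCCN(C)C)cc2c1`) gives 1.3 on the same scale. Compound 3 thus lies beyond the scatter from compound 1 and within the scatter of compound 2, so these last two cannot be told apart on this read-out.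

Compound 4 (`Cc1ccc2[nH]c(C(=O)N[C@H]3CCN(S(=O)(=O)N4CCOCC4)C[C@@H]3C(=O)NCCN(C)C)cc2c1`) keeps the core of compound 3 and changes only the group on the sulfonyl sulfur, with morpholin-4-yl in place of pyridin-3-yl (morpholin-4-yl in place of pyridin-3-yl on a sulfonyl sulfur). A six-membered aromatic ring leaves and a six-membered non-aromatic ring enters.

Among the measured compounds shown here, only one measured step changes a group on a sulfonyl sulfur with the core held constant. That step is a number 0.70 log units higher from compound 1 to compound 2 (beyond the scatter) and comes with 1,3-dimethyl-1H-pyrazol-4-yl in place of pyridazin-4-yl. It shows that a swap at this place can move the number by a modest amount. However, neither of its groups takes part in the present change, and no measured compound carries morpholin-4-yl, so it offers a rough size and no direction. The expected change is small, an estimated a number 0.10 log units lower from compound 3 to compound 4 (within the scatter) that stays within the scatter. For compound 4 the estimated value is 1.2 (expected range 0.7 to 1.7).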

Compound 4, distribution coefficient: 1
Compound 4: middle estimate off by 0.20 log units, on the high side; the measured number falls inside the stated range.
By their numbers in this assay, from the lowest: compounds 1, 4, 3 and 2 (each within the scatter of the next, the first and the last beyond it).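

In this assay, replacing pyridin-3-yl with morpholin-4-yl on the sulfonyl sulfur gives a number 0.30 log units lower from compound 3 to compound 4 (within the scatter), so this read-out cannot tell the two compounds apart, even though a six-membered aromatic ring has given way to a six-membered non-aromatic ring. Among the compounds shown here, this differs from the only earlier step at this place, a number 0.70 log units higher from compound 1 to compound 2 (beyond the scatter), and shows that a swap on the sulfonyl sulfur does not always move the number beyond the scatter; on the core of compound 3, an aromatic ring at this place is not needed for a value that close to that of compound 3. Nothing measured here explains why this swap leaves the number within the scatter.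

For the compounds shown here, it remains open whether morpholin-4-yl would behave the same way on the core of compound 1, where the only step seen at this place lies beyond the scatter. The compounds shown also leave open how piperidin-1-yl, which has a carbon in place of the morpholine oxygen, or an open-chain dimethylamino group would read on the sulfonyl sulfur.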